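The source may hold more compounds than are shown below. What is called first, only, known or untested is meant among the compounds shown, and "the series" means these compounds.

Measured so far: compound 1 `CC(=O)c1nc([N+](=O)[O-])c(Sc2cccc(Cl)c2Cl)s1`, which in a functional assay on HCT-116 cells (Homo sapiens) for antiproliferative activity, read by MTT assay, with a stated time of 72 h (a higher number here means a weaker inhibitor, a lower number a stronger inhibitor), gives 9290 nM. Compound 3 `O=C(Nc1ccccc1)c1nc([N+](=O)[O-])c(Sc2c(Cl)cncc2Cl)s1` gives 12400 nM in this assay. For compound 2 `CC(=O)c1nc([N+](=O)[O-])c(NCc2ccc(Cl)c(Cl)c2)s1` this assay reports only a limit, > 50000 nM.

Of the two numbers reported, compound 3 has the higher, yet it and compound 1 lie within the scatter of each other, so neither can be called the stronger inhibitor. Compound 4 `O=C(NCc1ccccc1)c1nc([N+](=O)[O-])c(Sc2c(Cl)cncc2Cl)s1` differs from compound 3 in one place: benzyl in place of phenyl on an amide-type nitrogen. For the measured compounds named here, no measured pair in this set shows the effect of that change, so no step size can be read from the data. The expected step is a 1.2-fold higher number from compound 3 to compound 4 (0.08 log units; within the scatter), small enough to stay within the scatter. Compound 4 is therefore estimated at 15000 nM, with a range from 5000 nM to 45000 nM.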

Compound 4, half-maximal inhibitory concentration: 13500 nM
Compound 4: the middle estimate sits 1.1-fold (0.05 log units) above what was measured; low and high end bracket the measured number.
By their numbers in this assay, from the lowest: compounds 1, 3 and 4 (each within the scatter of the next). At a limit, above all of these: compound 2.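

For the compounds shown here, this is the first pair in the set that differs in one place: with benzyl in place of phenyl on an amide-type nitrogen, this assay shows a 1.1-fold higher number from compound 3 to compound 4 (0.04 log units; within the scatter). On this nitrogen, then, the two groups cannot be told apart in this assay. Nothing given here bears on a cause for this result.

Still open, going by these compounds, is whether a longer chain such as phenethyl on that nitrogen, or an amine or a carboxylic acid on its aromatic ring, would move the number beyond the scatter.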